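Swapping the amide aryl group once more

A few compounds are considered here, and "the series" means these few. Any claim that something is new, unique, unknown or untested is made for them only; others in the source may bear on it.

Going by the values given here, in a functional assay on T47D cells (Homo sapiens) for inhibition, read by CCK-8 assay, with a stated time of 72 h, tested at 10 uM (on this read-out lower numbers stand for less inhibition of growth and higher numbers for more inhibition of growth at the one concentration tested), compound 2 `CN(C)C(=O)c1cc2cnc(Nc3ccc(NC(=O)C4(C(=O)Nc5cccc(F)c5)CC4)cc3)nc2n1C1CCCC1` gives -0.4%, the lowest of the two numbers known so far, while compound 1 `Cc1ccc(NC(=O)C2(C(=O)Nc3ccc(Nc4ncc5cc(C(=O)N(C)C)n(C6CCCC6)c5n4)cc3)CC2)cc1` gives 99.6%. Among the compounds with values here, the one measured step, a number 100 percentage points lower from compound 1 to compound 2 (beyond the scatter), changed the group on this same amide-type nitrogen and shows that a swap at this place can move the number widely. Compound 3 `CN(C)C(=O)c1cc2cnc(Nc3ccc(NC(=O)C4(C(=O)Nc5ccc(C(F)(F)F)cc5)CC4)cc3)nc2n1C1CCCC1` differs from compound 2 by 4-(trifluoromethyl)phenyl in place of 3-fluorophenyl on an amide-type nitrogen. A large move is possible in either direction, and a rise is judged somewhat more likely. Compound 3 is therefore expected to give 55%, within 5% to 100%. The expected step is a number 55.4 percentage points higher from compound 2 to compound 3 (beyond the scatter).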

Compound 3, percent growth inhibition at one concentration: 94.9%
For compound 3 the middle estimate is 39.9 percentage points below the measured one; the measured number falls inside the stated range.
By their numbers in this assay, from the lowest: compound 2; then compounds 3 and 1 (each within the scatter of the next).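

On the amide-type nitrogen, 4-(trifluoromethyl)phenyl in place of 3-fluorophenyl gives a number 95.3 percentage points higher from compound 2 to compound 3 (beyond the scatter) in this assay, so a fluorine-bearing phenyl group at this place does not always go with a low number. Trifluoromethyl in place of methyl on an aromatic carbon gives a number 4.7 percentage points lower from compound 1 to compound 3 (within the scatter), so this assay does not separate these two groups. No measurement available here explains the large gap to 3-fluorophenyl. Still open is whether the fluorine's ring position or the group itself decides the outcome. 4-Fluorophenyl or 3-(trifluoromethyl)phenyl would address that, while an amine on the ring remains untested among the compounds shown.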